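This account rests on a few compounds, and the source may have more. Where it says the series, first, only, none or still open, it means among the compounds named here.

Measured so far in a functional assay on CHO cells for agonist activity at Alpha-1D adrenergic receptor (Homo sapiens), read by FLIPR and calcium flux; a lower number here means that less compound is needed, a higher number that more compound is needed for the effect:
- compound 1 `c1cc(-c2ccn[nH]2)c2c(c1)C(c1ncc[nH]1)CC2`: 336 nM
- compound 2 `CS(=O)(=O)Nc1cccc2c1CCC2c1ncc[nH]1`: > 10000 nM
- compound 3 `Cc1ccc2c(c1NS(C)(=O)=O)CCC2c1ncc[nH]1`: > 10000 nM

Among the compounds with values here, compound 1 is the only member of the three with a numeric value in this assay. For compound 2 the value in this assay is a limit of the assay and not a number. For compound 3 the value in this assay is likewise a limit. Compound 2 therefore stands at the limit of > 10000 nM in this assay, at which 2 of the 3 values shown sit, and nothing more precise is known about where it lies.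

Of the measured steps, an at least 29-fold higher number from compound 1 to compound 2 (1.47 log units; beyond the scatter) is a large step and concerns the exchange of the whole aromatic substituent. a step that the two limits leave unreadable from compound 2 to compound 3 is a methyl-for-hydrogen change, but both ends sit at limits, so its size cannot be read.

Compound 4 `CCS(=O)(=O)Nc1cccc2c1CCC2c1ncc[nH]1` differs from compound 2 by methyl in place of hydrogen on a saturated chain carbon bound to a sulfonyl sulfur. Within the data shown here, the only measured methyl-for-hydrogen step, from compound 2 to compound 3, gives no readable size, and no other step touches the sulfonyl chain. With compound 2 already at the limit, the expected step that the limit leaves unreadable from compound 2 to compound 4 is none beyond the scatter. Compound 4 is therefore estimated at 15000 nM, with a range of 5000 nM to 40000 nM, and most likely reported again only as a limit.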

Compound 4, half-maximal effective concentration: > 10000 nM
Compound 4 ended at the assay's limit; the forecaster's own chance of this, stated with the estimate: 75%; the middle value does not contradict the limit.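

Working from compound 2, ethylsulfonyl in place of methylsulfonyl does not bring a numeric value in this assay: compound 4 stands at a limit of the assay, not at a number, so this change on the saturated chain carbon bound to a sulfonyl sulfur adds a second sulfonyl chain at that limit. The steps among compound 2, compound 3 and compound 4 cannot be read, since all three sit at the limit. The (ethylsulfonyl)amino group in place of 1H-pyrazol-5-yl gives an at least 29-fold higher number from compound 1 to compound 4 (1.47 log units; beyond the scatter), so in the compounds shown only compound 1 keeps a numeric value, and the series now reads: the limit of > 10000 nM in this assay, at which 3 of the 4 values shown sit.

From the compounds shown here alone, whether ethylsulfonyl and methylsulfonyl differ at all stays unknown while both sit at the limit. Also open, going by these compounds, is whether a longer chain on the sulfonyl sulfur, or an amine or a carboxylic acid in place of the (ethylsulfonyl)amino group, would give a numeric value.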